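Methoxy to Methylsulfanyl: Expecting a Step Within the Scatter

The source may report more compounds than this note shows. Statements on the series, on what has been measured and on what is new or still open speak of the compounds shown alone.

Compound 3 `COc1ccc(CNc2nc(SC)nc3ccccc23)cc1` is set against its two measured relatives, compound 1 `CSc1ccc(CNc2nc([SeH])nc3ccccc23)cc1` and compound 2 `CSc1nc(NCc2ccc([Se]C)cc2)c2ccccc2n1`. In a functional assay on CCRF-CEM cells (Homo sapiens) for cytotoxicity, read by MTT assay, with a stated time of 72 h (on this read-out higher numbers stand for weaker inhibition of growth and lower numbers for stronger inhibition of growth), compound 3 gives 93700 nM, the highest of the three numbers, although both neighbours sit within the scatter of it: compound 1 gives 71900 nM and compound 2 gives 63300 nM, so no order among the three can be claimed. The only single-point step among these, a 1.5-fold higher number from compound 2 to compound 3 (0.17 log units; within the scatter), exchanged a group containing selenium for a group containing oxygen on the same aromatic carbon and stayed within the scatter.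

Compound 4 `CSc1ccc(CNc2nc(SC)nc3ccccc23)cc1` has not yet been measured. It differs from compound 3 by methylsulfanyl in place of methoxy on an aromatic carbon. For the measured compounds named here, the one measured step that bears on this change is the exchange from compound 2 to compound 3, where a swap between two such groups on the same aromatic carbon moved the number only within the scatter. On that basis a step of similar or smaller size is expected here, with no direction beyond the scatter. Compound 4 is therefore estimated at 80000 nM in this assay, with a range from 40000 nM to 160000 nM. The step this estimate implies, a 1.2-fold lower number from compound 3 to compound 4 (0.07 log units; within the scatter), is expected to remain within the scatter.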

Compound 4, concentration for 50% growth inhibition: > 100000 nM
Compound 4: no number, only a limit (the forecaster's own chance of this, stated with the estimate: 10%); at least 1.2-fold (0.09 log units) between middle value and limit.
By their numbers in this assay, from the lowest: compounds 2, 1 and 3 (each within the scatter of the next). At a limit, above all of these: compound 4.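

In this assay compound 4 gives > 100000 nM, which is a limit of the assay and not a number, so the measurement gives only a floor for the change at this position: the limit of > 100000 nM in this assay, at which 1 of the 4 values shown sits. With methylsulfanyl in place of methoxy the reading is an at least 1.0-fold higher number from compound 3 to compound 4 (0.02 log units; that floor lies within the scatter), and the two steps that involve the selenium-bearing relatives read an at least 1.5-fold higher number from compound 2 to compound 4 (0.19 log units; that floor lies within the scatter) and an at least 1.3-fold higher number from compound 1 to compound 4 (0.14 log units; that floor lies within the scatter). The earlier compounds shown here could not show this: methylsulfanyl on this aromatic carbon, para to a large group, brings no sign of stronger inhibition of growth than methoxy, yet as all three floors stay within the scatter, no weakening can be claimed either.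

The compounds shown leave open how far compound 4 truly lies from compound 3, and so whether the exchange of methoxy for methylsulfanyl has any real effect on the number. They also leave open whether a different group on this aromatic carbon, such as an amine, a carboxylic acid or a longer chain, would move the number clearly beyond the scatter.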